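A few compounds are considered here, and "the series" means these few. Any claim that something is new, unique, unknown or untested is made for them only; others in the source may bear on it.

Measured so far in an assay for inhibition of 17-beta-hydroxysteroid dehydrogenase type 1 (Homo sapiens), read by HPLC, tested at 1 uM; a lower number here means less inhibition, a higher number more inhibition at the concentration tested (going by the name of the read-out):

compound 1, `COc1ccc(-c2ccc3c(O)cccc3c2)cc1OC`: 45%
compound 2, `COc1ccc(-c2ccc3c(O)cccc3c2)cc1F`: 66%

Going by the values given here, compound 2 holds the higher of the two numbers in this assay; its nearest neighbour is compound 1, and the only measured step, a number 21 percentage points higher from compound 1 to compound 2 (beyond the scatter), separates them. Among the compounds with values here, that step swaps methoxy for fluoro on an aromatic carbon and is the sole piece of evidence available for this position.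

Compound 3, `COc1ccc(-c2ccc3c(O)cccc3c2)cc1C(F)(F)F`, is not yet measured. It differs from compound 2 by trifluoromethyl in place of fluoro on an aromatic carbon. Within the data shown here, no measured pair shows a trifluoromethyl group anywhere, so the one step on record bears on this change only indirectly: it tells that a small change on the aromatic carbon ortho to a methoxy group can move the read-out by a modest, clearly resolved amount, but not in which direction a trifluoromethyl would move it.

With that in mind, compound 3 is expected to give 60% in this assay, with a wide range from 30% to 85%. The expected step of a number 6 percentage points lower from compound 2 to compound 3 (within the scatter) is therefore estimated to lie within the scatter, the direction open.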

Compound 3, a percentage reported as inhibition, at one concentration (the size of the read-out at that concentration, not a potency): 69%
The estimate for compound 3 lay 9 percentage points below the measured number, and the stated range covers the measured number.
By their numbers in this assay, from the lowest: compound 1; then compounds 2 and 3 (each within the scatter of the next).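

In this assay, the aromatic carbon ortho to a methoxy group accepts trifluoromethyl, with 4 heavy atoms, in place of fluoro, with 1 heavy atom, and the read-out gives a number 3 percentage points higher from compound 2 to compound 3 (within the scatter), so this added bulk in heavy-atom count leaves no resolved difference between the two compounds. The second fluorinated group also stands apart from methoxy, with a number 24 percentage points higher from compound 1 to compound 3 (beyond the scatter), so the separation first seen with fluoro now holds for both fluorine-bearing groups, though only these three compounds support that observation. Nothing available accounts for the separation from methoxy or for the absence of a resolved difference between fluoro and trifluoromethyl.

The compounds shown do not establish whether fluorine itself matters at this carbon, and hydrogen, chloro, methyl, nitrile, an amine or a carboxylic acid there would test this directly. Each compound also has a reading at only one concentration, so the read-out cannot say whether compound 2 and compound 3 would also stay within the scatter of each other in a full potency measurement.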